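The source may report more compounds than this note shows. Statements on the series, on what has been measured and on what is new or still open speak of the compounds shown alone.

Compound 1 `Oc1nc(NCC2CCCCC2)nc2ccc(Cl)cc12`: 80.3%
Compound 2 `C[C@@H](Nc1nc(O)c2cc(Cl)ccc2n1)C1CCCCC1`: 90.7%
Compound 3 `Oc1nc(NCc2ccccc2)nc2ccc(Cl)cc12`: 98.1%

Of the compounds shown here, three with a shared core have been measured in a functional assay on the whole organism (uterus) with Rattus norvegicus as the target, tested at 50 uM; a lower number here means a stronger effect, a higher number a weaker effect of the compound at the concentration tested. Compound 1 `Oc1nc(NCC2CCCCC2)nc2ccc(Cl)cc12` gives 80.3%. Compound 2 `C[C@@H](Nc1nc(O)c2cc(Cl)ccc2n1)C1CCCCC1` gives 90.7%, and compound 3 `Oc1nc(NCc2ccccc2)nc2ccc(Cl)cc12` gives 98.1%. Compound 3 holds the highest of the three numbers; its gap to compound 2 lies within the scatter, while the step of a number 17.8 percentage points higher from compound 1 to compound 3 (beyond the scatter) lies beyond it.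

Compound 4 `C[C@@H](Nc1nc(O)c2cc(Cl)ccc2n1)c1ccccc1` has not yet been measured. It differs from compound 3 by methyl in place of hydrogen on a saturated chain carbon bound to an aromatic carbon and a nitrogen on an aromatic ring. The same kind of change has been seen once before, on the cyclohexyl analogue, where the step of a number 10.4 percentage points higher from compound 1 to compound 2 (beyond the scatter) was modest but beyond the scatter. Compound 3, however, already stands close to the top of the percentage scale, so there is little room for a further rise. On that basis the step from compound 3 to compound 4 is expected to be small, a number 1.9 percentage points higher from compound 3 to compound 4 (within the scatter), within the scatter. The number for compound 4 in this assay is therefore estimated at 100%, with a range from 90% to 110%.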

Compound 4, a percentage reported as activity, at one concentration (the size of the read-out at that concentration, not a potency): 46.5%
Beside the measured number, compound 4's estimate is 53.5 percentage points above it; the whole stated range lies above it.
By their numbers in this assay, from the lowest: compound 4; then compound 1; then compounds 2 and 3 (each within the scatter of the next).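

In this assay, methyl in place of hydrogen on a saturated chain carbon bound to an aromatic carbon and a nitrogen on an aromatic ring gives a number 51.6 percentage points lower from compound 3 to compound 4 (beyond the scatter), so this small change at this position can produce a large shift in the number. The outcome of adding the methyl depends on whether the neighbouring ring is phenyl or cyclohexyl: the same change on two cores in this assay, a number 10.4 percentage points higher (beyond the scatter) from compound 1 to compound 2 and a number 51.6 percentage points lower (beyond the scatter) from compound 3 to compound 4, 62 percentage points apart, beyond the scatter of two such steps. The ring change depends on the methyl in turn, since with the methyl in place, phenyl in place of cyclohexyl gives a number 44.2 percentage points lower from compound 2 to compound 4 (beyond the scatter): the same change on two cores in this assay, a number 17.8 percentage points higher (beyond the scatter) from compound 1 to compound 3 and a number 44.2 percentage points lower (beyond the scatter) from compound 2 to compound 4, 62 percentage points apart, beyond the scatter of two such steps.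

The compounds shown leave open whether an ethyl group or a longer chain on that carbon would also lower the number. Going by these compounds, whether the mirror-image arrangement at that carbon would behave like compound 4 also remains open.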